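Removing a Propyl Chain from the Strongest Binder

The source may hold more compounds than are shown below. What is called first, only, known or untested is meant among the compounds shown, and "the series" means these compounds.

Three compounds built on a shared core were tested in an assay on CHO cells for displacement of a labelled ligand from prostaglandin D2 receptor 2 (Homo sapiens), read by scintillation counting; a higher number here means a weaker inhibitor, a lower number a stronger inhibitor. Compound 1, `O=C(O)COc1ccc(Cl)cc1C#Cc1ccncc1`, gives 601 nM. Compound 3, `CS(=O)(=O)Cc1cccc(C#Cc2cc(Cl)ccc2OCC(=O)O)c1`, gives 48 nM. Compound 2, `CCCc1ccncc1C#Cc1cc(Cl)ccc1OCC(=O)O`, gives 4.3 nM, the lowest of the three numbers; its nearest neighbour is compound 3 and its furthest is compound 1, and both gaps lie beyond the usual scatter, so compound 2 stands as the strongest inhibitor of the set.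

Compound 4, `O=C(O)COc1ccc(Cl)cc1C#Cc1cccnc1`, has not yet been measured. It differs from compound 2 in one place: hydrogen in place of propyl on an aromatic carbon. Among the compounds with values here, no measured pair isolates exactly this change, so the size of the step has to be judged indirectly. Compound 1, which likewise carries no chain on that ring, gives 601 nM. That comparison suggests the chain matters a great deal for binding in this assay. The loss of the chain is therefore expected to weaken binding clearly, an expected step of a 70-fold higher number from compound 2 to compound 4 (1.84 log units; beyond the scatter). Compound 4 is estimated at 300 nM, with a likely range from 60 nM to 1500 nM.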

Compound 4, inhibition constant: 117 nM
Compound 4: the middle estimate sits 2.6-fold (0.41 log units) above what was measured, within the range that was stated.
By their numbers in this assay, from the lowest: compound 2; then compound 3; then compound 4; then compound 1.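

In this assay, within the data shown here, hydrogen in place of propyl gives a 27-fold higher number from compound 2 to compound 4 (1.43 log units; beyond the scatter) and so, for the first time, sizes this one change directly: the propyl, on the aromatic carbon opposite the ring nitrogen, accounts for a large difference in binding. Without any chain, the ring itself still matters, since pyridin-3-yl in place of pyridin-4-yl gives a 5.1-fold lower number from compound 1 to compound 4 (0.71 log units; beyond the scatter) as a modest step beyond the scatter. Nothing available explains either step.

Open still is whether a methyl, an ethyl, a longer chain such as butyl, or an amine on that same carbon would bind as well as the propyl. Also open, going by these compounds, is whether a propyl on the pyridin-4-yl ring of compound 1 would give a step of similar size.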